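The source may hold more compounds than are shown below. What is called first, only, known or untested is meant among the compounds shown, and "the series" means these compounds.

Working notes on the series. In an assay on HEK293 cells for inhibition of solute carrier family 22 member 12 (Homo sapiens) (on this read-out higher numbers stand for weaker inhibition and lower numbers for stronger inhibition), compound 1 `NS(=O)(=O)CSc1nnc(Br)n1Cc1ccc(Br)c2ccccc12` gives 365000 nM, compound 2 `O=S(=O)(O)CSc1nnc(Br)n1Cc1ccc(Br)c2ccccc12` gives 14400 nM, and compound 3 `O=S(=O)(CSc1nnc(Br)n1Cc1ccc(Br)c2ccccc12)Nc1ccc(Cl)nc1Cl` gives 1660 nM, the lowest of the three numbers. The steps measured so far are a 25-fold lower number from compound 1 to compound 2 (1.40 log units; beyond the scatter), a 220-fold lower number from compound 1 to compound 3 (2.34 log units; beyond the scatter) and an 8.7-fold lower number from compound 2 to compound 3 (0.94 log units; beyond the scatter); each of them alters the group carried by the sulfonyl sulfur. Compound 4 `O=S(=O)(CSc1nnc(Br)n1Cc1ccc(Br)c2ccccc12)Nc1ccc(Br)nc1Br` differs from compound 3 only by 2,6-dibromopyridin-3-yl in place of 2,6-dichloropyridin-3-yl on a sulfonamide nitrogen. Among the compounds with values here, no measured step exchanges one halogen for another on the 2,6-dichloropyridin-3-yl group, so none bears directly on this change. The expectation in this assay is therefore a step of a 1.2-fold lower number from compound 3 to compound 4 (0.07 log units; within the scatter), not beyond the scatter. Compound 4 is estimated at 1400 nM, within 500 nM to 4000 nM.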

Compound 4, half-maximal inhibitory concentration: 5410 nM
Beside the measured number, compound 4's estimate is 3.9-fold (0.59 log units) below it, and the stated range ends below it.
By their numbers in this assay, from the lowest: compound 3; then compound 4; then compound 2; then compound 1.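

Within the data shown here, exchanging 2,6-dichloropyridin-3-yl for 2,6-dibromopyridin-3-yl on a sulfonamide nitrogen changes the read-out in this assay (a 3.3-fold higher number from compound 3 to compound 4 (0.51 log units; beyond the scatter)), so the halogens on this group matter, which no earlier step could show. The dibromo group still gives lower numbers than hydroxy on the sulfonyl sulfur (a 2.7-fold lower number from compound 2 to compound 4 (0.43 log units; beyond the scatter)) and than hydrogen on the sulfonamide nitrogen (a 67-fold lower number from compound 1 to compound 4 (1.83 log units; beyond the scatter)). Nothing measured here explains the halogen step.

Which of the two bromines carries the step remains open. So does the result for 2,6-difluoropyridin-3-yl or unsubstituted pyridin-3-yl on the same nitrogen.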